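The source may hold more compounds than are shown below. What is called first, only, known or untested is meant among the compounds shown, and "the series" means these compounds.

Measured compounds
- compound 1 `Cc1ccc(CN(C)C(=O)c2nn(-c3ccc(F)cc3)c(OC[C@@H](O)C[C@@H](O)CC(=O)O)c2C(C)C)cc1`: in a functional assay on L6 cells (Rattus norvegicus) for inhibition (a lower number here means a stronger inhibitor, a higher number a weaker inhibitor), compound 1 gives 1250 nM
- compound 2 `CC(C)c1c(C(=O)NCc2ccccn2)nn(-c2ccc(F)cc2)c1OC[C@@H](O)C[C@@H](O)CC(=O)O`: in this assay compound 2 gives "not determined" (no result reported)

Among the measured compounds shown here, compound 1 carries the only number; compound 2 adds a structure without a value. Compound 1 therefore stands alone as the reference, and nothing measured sits beside it for comparison.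

Compound 3 `CC(C)c1c(C(=O)NCc2ccccc2Cl)nn(-c2ccc(F)cc2)c1OC[C@@H](O)C[C@@H](O)CC(=O)O` has not been measured. It differs from compound 1 in one place, with this change: (2-chlorobenzyl)amino in place of methyl(4-methylbenzyl)amino on a carbonyl carbon. For the measured compounds named here, no measured step covers this kind of change, so the size of the effect cannot be read from the series. A moderate step in this assay is expected, more likely toward stronger inhibition than weaker, but possibly not beyond the scatter. For compound 3 the expected result in this assay is 800 nM, with a range from 250 nM to 2500 nM, which corresponds to an expected step of a 1.6-fold lower number from compound 1 to compound 3 (0.19 log units; within the scatter).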

Compound 3, half-maximal inhibitory concentration: 8450 nM
The estimate for compound 3 lay 11-fold (1.02 log units) below the measured number; the whole stated range lies below it.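

In this assay, the group on the carbonyl carbon has a clear influence: (2-chlorobenzyl)amino in place of methyl(4-methylbenzyl)amino gives a 6.8-fold higher number from compound 1 to compound 3 (0.83 log units; beyond the scatter), a change toward weaker inhibition. This single step changes several features at once, since the entering group carries the amide hydrogen and a chlorine while the leaving group carries two methyl groups, so the step cannot be assigned to any one of them. Nothing available bears on the reason for this loss.

Still open, on these data alone, is whether (4-methylbenzyl)amino or methyl(2-chlorobenzyl)amino on this carbonyl carbon would sit nearer compound 1 or compound 3, as either would separate the amide hydrogen from the ring substituents. Also open, as far as these compounds go, is how a longer chain, such as phenethylamino, would read at this place.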